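A few compounds are considered here, and "the series" means these few. Any claim that something is new, unique, unknown or untested is made for them only; others in the source may bear on it.

Measured compounds:
compound 1 `O=Cc1ccc(-c2cn3ccnc3c(-c3ccc4ncn(C5CCCCC5)c4c3)n2)cc1` — 31.5%
compound 2 `CC(=O)c1ccc(-c2cn3ccnc3c(-c3ccc4ncn(C5CCCCC5)c4c3)n2)cc1` — 2.82%
compound 3 `COc1ccccc1-c1cn2ccnc2c(-c2ccc3ncn(C4CCCCC4)c3c2)n1` — 8.07%

In a functional assay on SF-539 cells (Homo sapiens) for inhibition, read by sulforhodamine B assay, with a stated time of 48 h, tested at 10 uM (a lower number here means less inhibition, a higher number more inhibition at the concentration tested (going by the name of the read-out)), compound 1 gives 31.5%, the highest of the three numbers. Both measured steps away from it go down: a number 28.7 percentage points lower from compound 1 to compound 2 (beyond the scatter) and a number 23.4 percentage points lower from compound 1 to compound 3 (beyond the scatter), while between the other two, a number 5.3 percentage points higher from compound 2 to compound 3 (within the scatter), which is within the scatter. Compound 4 `O=Cc1ccc(-c2cn3ccnc3c(-c3ccc4ncn(Cc5ccccc5)c4c3)n2)cc1` differs from compound 1 by benzyl in place of cyclohexyl on an aromatic nitrogen. Going by the values given here, none of the measured steps bears on this change: all three alter the aryl group on the aromatic carbon and leave the ring nitrogen substituent untouched, so no step of like kind is available to scale the effect. The expectation therefore rests on compound 1 alone and carries a wide range. Compound 4 is expected at 28% (range 5% to 55%), which estimates the step of a number 3.5 percentage points lower from compound 1 to compound 4 (within the scatter) as one that stays within the scatter.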

Compound 4, a percentage reported as inhibition, at one concentration (the size of the read-out at that concentration, not a potency): 31.5%
Beside the measured number, compound 4's estimate is 3.5 percentage points below it, and the stated range covers the measured number.
By their numbers in this assay, from the lowest: compounds 2 and 3 (each within the scatter of the next); then compounds 1 and 4 (each within the scatter of the next).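

In this assay, going by these compounds alone, benzyl in place of cyclohexyl on the aromatic nitrogen gives no change at the digits printed from compound 1 to compound 4 (within the scatter), the first reading at this position. With the 4-formylphenyl group held fixed, the read-out does not separate the aromatic ring from the non-aromatic one here, whereas all earlier steps changed the aryl group on the aromatic carbon. No measurement bearing on this result is available to explain it.

Still open, from the compounds shown here alone, is whether an amine, a carboxylic acid or a longer chain on this nitrogen would leave the number unmoved. Also open, going by these compounds, is whether benzyl behaves the same alongside the 4-acetylphenyl or 2-methoxyphenyl groups.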